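Cyclohexyl for 2-chlorophenyl in a cytotoxicity series

A few compounds are considered here, and "the series" means these few. Any claim that something is new, unique, unknown or untested is made for them only; others in the source may bear on it.

Compound 1 `CCC1(Cc2ccccc2)OS(=O)(=O)C=C1OCC(=O)OC` in an ADME assay on HEL cells (Homo sapiens) for cytotoxicity, with a stated time of 3 days (a higher number here means that more compound is tolerated, a lower number that less compound is tolerated), gives > 400000 nM, a limit of the assay.
Compound 2 `CCC1(Cc2ccccc2)OS(=O)(=O)C=C1OCc1ccc(OC)cc1` gives >= 200000 nM, also a limit.
Compound 3 `CCC1(Cc2ccccc2)OS(=O)(=O)C=C1OCc1ccccc1Cl` gives >= 20000 nM, again a limit.

Compound 3 thus stands on a limit, and the two other values shown are limits as well (the limit of > 400000 nM in this assay, at which 1 of the 3 values shown sits, (the limit of >= 200000 nM in this assay, at which 1 of the 3 values shown sits), (the limit of >= 20000 nM in this assay, at which 1 of the 3 values shown sits)). The steps that alter the same place, a step that the two limits leave unreadable from compound 1 to compound 3 and a step that the two limits leave unreadable from compound 2 to compound 3, are not readable; both ends of each are limits, so no size or direction can be taken from them. Compound 4 `CCC1(Cc2ccccc2)OS(=O)(=O)C=C1OCC1CCCCC1` carries cyclohexyl in place of 2-chlorophenyl on a saturated chain carbon bound to an oxygen on an unsaturated carbon. In this assay compound 4 is expected near 100000 nM, within 20000 nM to 400000 nM. The step that the limit leaves unreadable from compound 3 to compound 4 that this estimate implies is expected to show no direction beyond the scatter, and a further limit is likely.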

Compound 4, minimum cytotoxic concentration: >= 200000 nM
Compound 4: only a limit was reported; the forecaster's own chance of this, stated with the estimate: 80%; middle value at least 2.0-fold (0.30 log units) from the limit.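

For the compounds shown here, compound 4 is a limit, as are compound 1, compound 2 and compound 3, so no step to compound 4 can be read in this assay. The compounds shown leave open whether any of these groups changes the tolerated concentration at all.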